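From Aryl Sulfonamide to Aryl Sulfonate: Compound 4

A few compounds are considered here, and "the series" means these few. Any claim that something is new, unique, unknown or untested is made for them only; others in the source may bear on it.

Compound 1, `CC(C)NS(=O)(=O)c1ccc2c(c1)C(n1ccccc1=O)=CC(C)(C)O2`: 676 nM
Compound 2, `CC1(C)C=C(n2ccccc2=O)c2cc(S(=O)(=O)NCc3ccccc3)ccc2O1`: 525 nM
Compound 3, `COc1ccc(NS(=O)(=O)c2ccc3c(c2)C(n2ccccc2=O)=CC(C)(C)O3)cc1`: 117 nM

In a functional assay with Rattus norvegicus as the target (a higher number here means that more compound is needed for the effect, a lower number that less compound is needed), compound 3 stands lowest of the three numbers; both a 5.8-fold lower number from compound 1 to compound 3 (0.76 log units; beyond the scatter) and a 4.5-fold lower number from compound 2 to compound 3 (0.65 log units; beyond the scatter) lie beyond the scatter, whereas a 1.3-fold lower number from compound 1 to compound 2 (0.11 log units; within the scatter) does not. Compound 4, `CC1(C)C=C(n2ccccc2=O)c2cc(S(=O)(=O)Oc3ccccc3)ccc2O1`, differs from compound 3 by phenoxy in place of (4-methoxyphenyl)amino on a sulfonyl sulfur. For the measured compounds named here, no measured step bears directly on this exchange, since every step so far varied only the substituent on the sulfonamide nitrogen. Because the gain toward compound 3 came with a 4.5-fold lower number from compound 2 to compound 3 (0.65 log units; beyond the scatter), giving up the (4-methoxyphenyl)amino group is expected to move the number back upward, a 3.4-fold higher number from compound 3 to compound 4 (0.53 log units; beyond the scatter). Compound 4 is therefore estimated at 400 nM, within a range from 120 nM to 1500 nM.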

Compound 4, half-maximal effective concentration: 2.51 nM
Estimate against measurement, compound 4: 160-fold (2.20 log units) above; measured number outside the range, below it.
By their numbers in this assay, from the lowest: compound 4; then compound 3; then compounds 2 and 1 (each within the scatter of the next).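

In this assay, phenoxy on the sulfonyl sulfur outdoes all three amino groups, with a 47-fold lower number from compound 3 to compound 4 (1.67 log units; beyond the scatter) and a 210-fold lower number from compound 2 to compound 4 (2.32 log units; beyond the scatter) and also a 270-fold lower number from compound 1 to compound 4 (2.43 log units; beyond the scatter) as its steps. Changes among the amino groups had brought modest steps at most, so this place proves able to carry far larger differences than those compounds revealed. No measurement shown accounts for the size of this gain.

Compound 4 differs from compound 3 both in the atom bound to the sulfur and in the loss of the methoxy group, and these two changes remain unseparated. Phenylamino or 4-methoxyphenoxy on the sulfonyl sulfur would tell them apart.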